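Swapping a phenethyl ether for a pyridylmethyl ether

The source may hold more compounds than are shown below. What is called first, only, known or untested is meant among the compounds shown, and "the series" means these compounds.

Measured so far:
- compound 1 `CCCn1ccc2cc(-c3ccc(Oc4ccccc4)nc3)cc(Cl)c2c1=O`: 501 nM in a functional assay on CHO cells for agonist activity at metabotropic glutamate receptor 2 (Homo sapiens), read by GTPgammaS binding; on this read-out lower numbers stand for an effect already at smaller amounts and higher numbers for an effect only at larger amounts of compound
- compound 2 `CCCn1ccc2cc(-c3ccc(OCCc4ccccc4)nc3)cc(Cl)c2c1=O`: 631 nM in this assay

Compound 2 holds the highest of the two numbers, yet its gap to compound 1 is small: a 1.3-fold higher number from compound 1 to compound 2 (0.10 log units; within the scatter). Both numbers therefore sit together within the usual scatter.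

Compound 3 `CCCn1ccc2cc(-c3ccc(OCc4cccnc4)nc3)cc(Cl)c2c1=O` keeps the shared core and changes only the group on the oxygen: pyridin-3-yl in place of benzyl on a saturated chain carbon bound to an oxygen on an aromatic ring. Going by the values given here, none of the measured steps bears on this change; the one step available, from compound 1 to compound 2, exchanged phenyl for phenethyl on that oxygen and was a 1.3-fold higher number from compound 1 to compound 2 (0.10 log units; within the scatter), so it only shows that the group on the oxygen can vary without a shift beyond the scatter. On that basis no step beyond the scatter is expected for compound 3, and its step from compound 2 is estimated as a 1.1-fold higher number from compound 2 to compound 3 (0.05 log units; within the scatter). For compound 3 the estimate in this assay is 700 nM, within 250 nM to 2000 nM.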

Compound 3, half-maximal effective concentration: 316 nM
Beside the measured number, compound 3's estimate is 2.2-fold (0.35 log units) above it; low and high end bracket the measured number.
By their numbers in this assay, from the lowest: compounds 3, 1 and 2 (each within the scatter of the next).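

Going by these compounds alone, the swap of benzyl for pyridin-3-yl on that saturated chain carbon brings a ring nitrogen, counted as a hydrogen-bond acceptor, onto this side of the molecule for the first time, and in this assay it gives a 2.0-fold lower number from compound 2 to compound 3 (0.30 log units; within the scatter). Against the phenyl ether the picture is the same, with a 1.6-fold lower number from compound 1 to compound 3 (0.20 log units; within the scatter), so at this oxygen a ring holding nitrogen fits the same range of numbers as rings of carbon only, although the swap also shortens the chain from phenethyl to (pyridin-3-yl)methyl. No measurement shown here explains these numbers.

The ring nitrogen and the shorter chain cannot be told apart from these compounds, and a plain benzyl on the oxygen would separate them. On these data alone, how a morpholine or a carboxylic acid at this place would read remains open.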